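The source may report more compounds than this note shows. Statements on the series, on what has been measured and on what is new or still open speak of the compounds shown alone.

Measured so far in an ADME assay on A549 cells (Homo sapiens) for cytotoxicity, read by resazurin assay, with a stated time of 48 h; on this read-out lower numbers stand for higher toxicity in this test and higher numbers for lower toxicity in this test:
compound 1 `CCCN(CCC)c1ccc(NC(=O)c2cc(Cl)ccc2O)c(Cl)c1`, 10700 nM;
compound 2 `O=C(Nc1ccc(NCc2ccc(C(F)(F)F)cc2)cc1Cl)c1cc(Cl)ccc1O`, 62700 nM;
compound 3 `O=C(Nc1ccc(NCc2ccc3cn[nH]c3c2)cc1Cl)c1cc(Cl)ccc1O`, 45300 nM.

Compound 1 gives the lowest of the three numbers, and both compound 2 and compound 3 stand beyond the scatter above it. Going by the values given here, the only step between measured compounds, a 1.4-fold lower number from compound 2 to compound 3 (0.14 log units; within the scatter), concerns the group on the saturated chain carbon and says nothing about the group on the aromatic carbon of the core.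

Compound 4 `CC(C)(CCO)Nc1ccc(NC(=O)c2cc(Cl)ccc2O)c(Cl)c1` carries (3-hydroxy-1,1-dimethylpropyl)amino in place of dipropylamino on an aromatic carbon. Among the compounds with values here, no measured step bears on this change. Within the data shown here, the sole pointer is that compound 2 and compound 3, which also differ from compound 1 at that aromatic carbon, give higher numbers. A modest rise is therefore expected, a 2.3-fold higher number from compound 1 to compound 4 (0.37 log units; beyond the scatter), with a wide range. Compound 4 is estimated at 25000 nM (8000 nM to 80000 nM) in this assay.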

Compound 4, half-maximal cytotoxic concentration: 170000 nM
Compound 4: middle estimate off by 6.8-fold (0.83 log units), on the low side; measured number outside the range, above it.
By their numbers in this assay, from the lowest: compound 1; then compounds 3 and 2 (each within the scatter of the next); then compound 4.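

In this assay, the group on this aromatic carbon of the shared core can move the number strongly: a 16-fold higher number from compound 1 to compound 4 (1.20 log units; beyond the scatter) comes with (3-hydroxy-1,1-dimethylpropyl)amino in place of dipropylamino. Both groups have the same heavy-atom count, so this change moves the number without any change in that count. No measurement at hand explains the step.

Which feature of the entering group goes with the step remains open. A 3-hydroxypropylamino group without the two methyl groups, or a methoxy group in place of the hydroxyl, would help separate them.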